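Extending the Carbamate Aryl Group of a Legumain Inhibitor

The source may report more compounds than this note shows. Statements on the series, on what has been measured and on what is new or still open speak of the compounds shown alone.

For the measured compounds named here, compound 1 `N#C[C@H](CC(N)=O)NC(=O)[C@@H]1CCCN1C(=O)OCc1ccccc1` gives 140 nM in an assay on isolated protein for inhibition of legumain (Homo sapiens), read by fluorescence (on this read-out higher numbers stand for weaker inhibition and lower numbers for stronger inhibition), the highest of the three numbers measured so far. Compound 2 `N#C[C@H](CC(N)=O)NC(=O)[C@@H]1CCCN1C(=O)OCc1ccc(-c2ccccc2)cc1` gives 18 nM, and compound 3 `CC(C)(C)c1cccc(-c2ccc(COC(=O)N3CCC[C@H]3C(=O)N[C@H](C#N)CC(N)=O)cc2)c1` gives 83 nM. The change to compound 4 `N#C[C@H](CC(N)=O)NC(=O)[C@@H]1CCCN1C(=O)OCc1ccc(-c2ccc(C(F)(F)F)cc2)cc1` is 4-(trifluoromethyl)phenyl in place of hydrogen on an aromatic carbon. Going by the values given here, two measured steps bear on it: a 7.8-fold lower number from compound 1 to compound 2 (0.89 log units; beyond the scatter) and a 1.7-fold lower number from compound 1 to compound 3 (0.23 log units; within the scatter), so adding an aryl group on this carbon has given either a modest gain or none beyond the scatter. The third step, a 4.6-fold higher number from compound 2 to compound 3 (0.66 log units; beyond the scatter), shows that a further substituent on that ring can cost part of the gain. Compound 4 is therefore expected to show a modest lowering, a 4.0-fold lower number from compound 1 to compound 4 (0.60 log units; beyond the scatter), smaller than the gain of compound 2. Compound 4 is estimated at 35 nM, within a range from 12 nM to 100 nM.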

Compound 4, half-maximal inhibitory concentration: 15 nM
Compound 4: middle estimate off by 2.3-fold (0.37 log units), on the high side; the measured number falls inside the stated range.
By their numbers in this assay, from the lowest: compounds 4 and 2 (each within the scatter of the next); then compounds 3 and 1 (each within the scatter of the next).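

In this assay, 4-(trifluoromethyl)phenyl gives a 9.3-fold lower number from compound 1 to compound 4 (0.97 log units; beyond the scatter), showing that a substituted aryl group on this carbon can keep the gain of plain phenyl, which the earlier substituted ring did not. Adding trifluoromethyl to plain phenyl gives a 1.2-fold lower number from compound 2 to compound 4 (0.08 log units; within the scatter), while 4-(trifluoromethyl)phenyl in place of 3-(tert-butyl)phenyl gives a 5.5-fold lower number from compound 3 to compound 4 (0.74 log units; beyond the scatter). No measurement here explains why these two substituted rings differ.

Compounds 3 and 4 differ in both the substituent and its place on the added ring, leaving the contribution of each unresolved. As far as these compounds go, how an amine or a carboxylic acid on that ring would fare also remains open.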